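Benzoxazolyl for phenyl on the pyrrolidinone series

This account rests on a few compounds, and the source may have more. Where it says the series, first, only, none or still open, it means among the compounds named here.

Compound 3 `O=C(O)c1csc(SCCN2C(=O)CC[C@@H]2/C=C/[C@@H](O)Cc2cccc(-c3ccccc3)c2)n1` is the reference point of the series. In an assay on CHO cells for displacement of a labelled ligand from prostaglandin E2 receptor EP2 subtype (Mus musculus), read by scintillation counting, with a stated time of 60 min (on this read-out lower numbers stand for stronger inhibition and higher numbers for weaker inhibition), compound 3 gives 3 nM, the lowest of the two numbers recorded. Going by the values given here, the nearest number belongs to compound 2 `O=C(O)CCCSCCN1C(=O)CC[C@@H]1/C=C/[C@@H](O)Cc1cccc(-c2cc3ccccc3o2)c1`, which in this assay gives 2000 nM; compound 2 differs from compound 3 in both the acid-bearing end and the aryl substituent, so no single step links them. Compound 1 `O=C(O)CCCSCCN1C(=O)CC[C@@H]1/C=C/[C@@H](O)Cc1cccc(N2Cc3ccccc3C2)c1` gives > 10000 nM in this assay, which is a limit of the assay and not a number (the limit of > 10000 nM in this assay, at which 1 of the 3 values shown sits).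

The step under consideration is the change from compound 3 to compound 4 `Cc1cccc2oc(-c3cccc(C[C@H](O)/C=C/[C@H]4CCC(=O)N4CCSc4nc(C(=O)O)cs4)c3)nc12`: 4-methyl-1,3-benzoxazol-2-yl in place of phenyl on an aromatic carbon. Among the compounds with values here, the only measured step touching the same position is an at least 5.0-fold lower number from compound 1 to compound 2 (0.69 log units; beyond the scatter), where a bicyclic aromatic group in place of a bicyclic non-aromatic one improved the number. That step starts from a limit, so its size is uncertain, and it sits on a different acid-bearing end.

A bicyclic heteroaromatic group at this position therefore appears tolerated, though the very low number of compound 3 leaves more room to rise than to fall. For compound 4 the expected outcome is a step of a 2.7-fold higher number from compound 3 to compound 4 (0.43 log units; beyond the scatter) in this assay, a number close to that of compound 3. The estimate for compound 4 is 8 nM, in the range 2 nM to 40 nM.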

Compound 4, inhibition constant: 22 nM
Compound 4: the middle estimate sits 2.8-fold (0.44 log units) below what was measured; the range from low to high includes it.
By their numbers in this assay, from the lowest: compound 3; then compound 4; then compound 2. At a limit, above all of these: compound 1.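

Putting 4-methyl-1,3-benzoxazol-2-yl in place of phenyl gives a 7.3-fold higher number from compound 3 to compound 4 (0.87 log units; beyond the scatter) in this assay, a modest loss. The earlier step compared two bicyclic groups on a different acid-bearing end, whereas this one sets a bicyclic group directly against phenyl on the same core. It shows that this position accepts the larger group, with its two hydrogen-bond acceptors where phenyl has none, at a measurable but limited price. Nothing measured here tells which feature of the entering group accounts for the step.

The compounds shown leave open how much of the step belongs to the methyl group and how much to the ring system itself; an unsubstituted 1,3-benzoxazol-2-yl group, or a pyridyl group in place of phenyl, would separate these contributions. Also open, from the compounds shown here alone, is whether the same replacement carries the same cost on the open-chain acid end of compound 1 and compound 2.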